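The source may report more compounds than this note shows. Statements on the series, on what has been measured and on what is new or still open speak of the compounds shown alone.

Compound 2, whose structure is `CO[C@@]12CCN(C)C[C@H]1[C@H](c1ccc(C)cc1)C(C#N)=C(N)O2`, gives 13200 nM in a functional assay on trachea (Cavia porcellus); a higher number here means a weaker inhibitor, a lower number a stronger inhibitor. Among the measured compounds shown here, it stands as the lower of the two numbers measured so far, the other coming from compound 1, with the structure `CO[C@@]12CCN(C)C[C@H]1[C@H](c1ccccc1)C(C#N)=C(N)O2`, which in this assay gives 19800 nM. For the measured compounds named here, the only step between these two, a 1.5-fold lower number from compound 1 to compound 2 (0.18 log units; within the scatter), is a methyl in place of hydrogen on an aromatic carbon and stays within the scatter.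

Compound 3, with the structure `COc1ccc([C@@H]2C(C#N)=C(N)O[C@]3(OC)CCN(C)C[C@@H]23)cc1`, differs from compound 2 by methoxy in place of methyl on an aromatic carbon. Going by the values given here, this change sits on the same aromatic carbon that the earlier step touched, so the step from compound 1 to compound 2 is the one measurement that bears on it, and that step was small. Nothing measured here tells how a methoxy at that place compares with a methyl, so the expectation for compound 3 rests on the earlier step alone, and it is for no movement beyond the scatter in this assay, that is a step of about a 1.0-fold lower number from compound 2 to compound 3 (0.01 log units; within the scatter). Compound 3 is therefore expected to give about 13000 nM in this assay, within a range from 5000 nM to 35000 nM.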

Compound 3, half-maximal inhibitory concentration: 23100 nM
For compound 3 the middle estimate is 1.8-fold (0.25 log units) below the measured one; low and high end bracket the measured number.
By their numbers in this assay, from the lowest: compounds 2, 1 and 3 (each within the scatter of the next).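

In this assay, at this place on an aromatic carbon, para to a large group, putting methoxy in place of methyl gives a 1.8-fold higher number from compound 2 to compound 3 (0.24 log units; within the scatter), and putting methoxy in place of hydrogen gives a 1.2-fold higher number from compound 1 to compound 3 (0.07 log units; within the scatter); both steps lie within the scatter. Together with the earlier methyl step, this means that hydrogen, methyl and methoxy at this one place cannot be told apart in this assay, even though methoxy is the only one of the three that brings an oxygen and a hydrogen-bond acceptor. Nothing available here offers an explanation for this flat result.

The three compounds leave open whether a group of a different kind at this place, such as an amine, a carboxylic acid or a longer chain, would move the number beyond the scatter. They also leave open how the number responds to changes elsewhere on the shared core, for instance at the nitrile, since all three compounds carry it unchanged.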